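A few compounds are considered here, and "the series" means these few. Any claim that something is new, unique, unknown or untested is made for them only; others in the source may bear on it.

Working notes on the shared core of compound 1 `S=C(N/N=C/c1cccs1)Nc1ccccc1`. In a functional assay on 786-0 cells (Homo sapiens) for inhibition, read by sulforhodamine B assay, with a stated time of 48 h (a lower number here means a stronger inhibitor of growth, a higher number a weaker inhibitor of growth), compound 1 gives 50400 nM. Compound 2 `S=C(N/N=C/c1cccs1)Nc1cccc2ccccc12` gives 15200 nM in this assay. Compound 3 `CCc1ccc(NC(=S)N/N=C/c2cccs2)cc1` gives 82600 nM in this assay; it stands at the high end of the three numbers, with compound 1 within the scatter of it and compound 2 beyond the scatter. For the measured compounds named here, the only single-point step measured so far, a 1.6-fold higher number from compound 1 to compound 3 (0.21 log units; within the scatter), is within the scatter.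

Compound 4 `Cc1ccc(NC(=S)N/N=C/c2cccs2)cc1` is not yet measured. It differs from compound 3 by hydrogen in place of methyl on a saturated chain carbon bound to an aromatic carbon. The step that bears on this is a 1.6-fold higher number from compound 1 to compound 3 (0.21 log units; within the scatter), where hydrogen and ethyl at the same place gave numbers that do not separate; methyl sits between those two in size. No step beyond the scatter is therefore expected in this assay, at most a slight drift toward a lower number because of 50400 nM for compound 1. Compound 4 is expected to give 65000 nM, between 30000 nM and 140000 nM. That estimate means an expected step of a 1.3-fold lower number from compound 3 to compound 4 (0.10 log units; within the scatter), within the scatter.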

Compound 4, concentration for 50% growth inhibition: 19500 nM
Compound 4: middle estimate off by 3.3-fold (0.52 log units), on the high side; measured number outside the range, below it.
By their numbers in this assay, from the lowest: compounds 2 and 4 (each within the scatter of the next); then compounds 1 and 3 (each within the scatter of the next).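

In this assay, methyl at this place separates from both hydrogen and ethyl: shortening ethyl to methyl gives a 4.2-fold lower number from compound 3 to compound 4 (0.63 log units; beyond the scatter), and methyl in place of hydrogen on the aromatic carbon gives a 2.6-fold lower number from compound 1 to compound 4 (0.41 log units; beyond the scatter). Hydrogen and ethyl themselves do not separate, at a 1.6-fold higher number from compound 1 to compound 3 (0.21 log units; within the scatter), so across compound 1, compound 3 and compound 4 the number does not follow chain length but dips at methyl alone. Nothing at hand accounts for this dip.

From the compounds shown here alone, whether the dip belongs to methyl alone, or also appears with a methoxy group, a chlorine atom or a longer chain such as propyl at the same place, stays open. Going by these compounds, whether the same steps appear in any other assay also stays open.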